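The compounds below may be only part of what the source reports. "The series", "measured", "known", "first", "only" and "open" are said of these compounds alone.

Three close relatives have been tested in an in vitro ADME assay on microsomes from liver (Homo sapiens) for metabolic stability, tested at 5 uM (on this read-out lower numbers stand for a shorter-lived compound and higher numbers for a longer-lived compound), all built on one shared core. Compound 1 `CC(C)CCn1nc(-c2cccs2)c(O)c(C2=NS(=O)(=O)c3cc(S(=O)(=O)N(C)C)ccc3N2)c1=O` gives 0.183 h, and compound 2 `CC(C)CCn1nc(-c2ccn(C)c2)c(O)c(C2=NS(=O)(=O)c3cc(NS(C)(=O)=O)ccc3N2)c1=O` gives 0.633 h. Compound 3 `COC(C)(C)CCn1nc(-c2cccs2)c(O)c(C2=NS(=O)(=O)c3cc(NS(C)(=O)=O)ccc3N2)c1=O` gives > 1 h, which is a limit of the assay and not a number. That makes compound 3 the only one of the three without an exact figure, as the limit of > 1 h in this assay, at which 1 of the 3 values shown sits, records.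

Compound 4 `CS(=O)(=O)Nc1ccc2c(c1)S(=O)(=O)N=C(c1c(O)c(-c3cccs3)nn(CCC3CCC3)c1=O)N2` has not yet been measured. It differs from compound 3 in one place: cyclobutyl in place of 1-methoxy-1-methylethyl on a saturated chain carbon, two bonds along the chain from an aromatic nitrogen. Put in words, cyclobutyl stands in place of 1-methoxy-1-methylethyl on a saturated chain carbon, so that 3-methoxy-3-methylbutyl becomes 2-cyclobutylethyl.

Going by the values given here, no two measured compounds differ in only one place, so no measured step sets the size of this change. The nearest guide is loose, since the chain of compound 4 lacks an oxygen, like the chains of compound 1 at 0.183 h and compound 2 at 0.633 h, although both also differ from compound 4 elsewhere. On that basis, a moderate shortening of the half-life is expected, with an estimated change an at least 2.0-fold lower number from compound 3 to compound 4 (0.30 log units; that floor lies within the scatter). For compound 4 the expected half-life is 0.5 h, with an estimated range of 0.2 h to 1.1 h.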

Compound 4, half-life: > 1 h
Compound 4: a limit, no number; the forecaster's own chance of this, stated with the estimate: 20%; middle value at least 2.0-fold (0.30 log units) from the limit.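

The results for compound 3 and compound 4 in this assay are both limits of the assay and not numbers, so the step between them cannot be read: the limit of > 1 h in this assay, at which 2 of the 4 values shown sit.

The compounds shown leave open whether 2-cyclobutylethyl in place of 3-methoxy-3-methylbutyl changes the half-life at all, and if so, by how much.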